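The source may report more compounds than this note shows. Statements on the series, on what has been measured and on what is new or still open speak of the compounds shown alone.

Going by the values given here, compound 2 `Oc1nc2nonc2nc1Nc1ccc(OC(F)F)cc1` stands as the higher of the two numbers so far in an assay on mitochondria from L6 cells (Rattus norvegicus) for activation, with a stated time of 90 min (on this read-out lower numbers stand for an effect already at smaller amounts and higher numbers for an effect only at larger amounts of compound), where compound 2 gives 20600 nM, while compound 1 `Oc1nc2nonc2nc1Nc1ccc(OCc2ccccc2)cc1` gives 2400 nM. Among the compounds with values here, the single known step, an 8.6-fold higher number from compound 1 to compound 2 (0.93 log units; beyond the scatter), altered the same group but does not match the change toward compound 3 `Oc1nc2nonc2nc1Nc1ccc(OC(F)(F)Cl)cc1`, which is chloro in place of hydrogen on a saturated chain carbon bound to two fluorine atoms and an oxygen on an aromatic ring. Within the data shown here, with no step that bears directly on it, the expected step of a 1.7-fold lower number from compound 2 to compound 3 (0.23 log units; within the scatter) is estimated to stay within the scatter or to be a small lowering. Compound 3 is therefore expected to give about 12000 nM, with a range from 3500 nM to 40000 nM.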

Compound 3, half-maximal effective concentration: 1900 nM
Beside the measured number, compound 3's estimate is 6.3-fold (0.80 log units) above it, outside the stated range (below it).
By their numbers in this assay, from the lowest: compounds 3 and 1 (each within the scatter of the next); then compound 2.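

In this assay, the change at this saturated chain carbon is sensitive to a single atom: chloro in place of hydrogen gives an 11-fold lower number from compound 2 to compound 3 (1.04 log units; beyond the scatter). With chloro(difluoro)methyl in place of benzyl on the oxygen, the result is a 1.3-fold lower number from compound 1 to compound 3 (0.10 log units; within the scatter), so this small group stays within the scatter of the benzyl group, which difluoromethyl did not. Nothing available explains why the chloro has this effect. The compounds shown leave open what bromo or a third fluorine in place of the chloro would give. They also leave open whether a longer chain on the oxygen would keep the number of compound 3.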